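Cyano in place of benzoyl in a growth inhibition series

A few compounds are considered here, and "the series" means these few. Any claim that something is new, unique, unknown or untested is made for them only; others in the source may bear on it.

Among the compounds with values here, in a functional assay on MCF7 cells (Homo sapiens) for inhibition, read by sulforhodamine B assay, with a stated time of 48 h, tested at 50 uM (a lower number here means less inhibition of growth, a higher number more inhibition of growth at the concentration tested), compound 1 `COc1ccc([C@@H]2C/C(=N/OCc3cn(-c4ccc(O)cc4)nn3)c3cc(CC=C(C)C)c(OC)cc3O2)cc1` gives 63% and compound 2 `COc1ccc([C@@H]2C/C(=N/OCc3cn(-c4ccc(C(=O)c5ccccc5)cc4)nn3)c3cc(CC=C(C)C)c(OC)cc3O2)cc1` gives 41%, so compound 2 holds the lower of the only two numbers available. Within the data shown here, the single measured step, which puts benzoyl in place of hydroxy on an aromatic carbon, is a number 22 percentage points lower from compound 1 to compound 2 (beyond the scatter).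

The next comparison concerns compound 3 `COc1ccc([C@@H]2C/C(=N/OCc3cn(-c4ccc(C#N)cc4)nn3)c3cc(CC=C(C)C)c(OC)cc3O2)cc1`, which has cyano in place of benzoyl on an aromatic carbon, para to a large group: cyano in place of benzoyl on an aromatic carbon. Here the benzoyl leaves the same place where it entered in the measured step, so that modest step is the only guide. Among the measured compounds shown here, no measured compound carries cyano, and cyano is not hydroxy, so a full return to the value of compound 1 is not assumed. Part of the gap may be recovered, and a smaller upward move is therefore expected in this assay. The expected change is a number 11 percentage points higher from compound 2 to compound 3 (beyond the scatter). For compound 3 the estimated value is 52%, with an expected range of 35% to 70%.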

Compound 3, percent growth inhibition at one concentration: 40%
Estimate against measurement, compound 3: 12 percentage points above; the range from low to high includes it.
By their numbers in this assay, from the lowest: compounds 3 and 2 (each within the scatter of the next); then compound 1.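

Putting cyano in place of benzoyl on the aromatic carbon, para to a large group, gives a number 1 percentage points lower from compound 2 to compound 3 (within the scatter) in this assay even though a group with a six-membered aromatic ring gives way to one with no ring at all. The size of the group and the presence of that ring therefore do not separate these two compounds in this read-out. Cyano in place of hydroxy gives a number 23 percentage points lower from compound 1 to compound 3 (beyond the scatter) and benzoyl in place of hydroxy gives a number 22 percentage points lower from compound 1 to compound 2 (beyond the scatter) so among these three compounds hydroxy is the only group that stands apart, and two very different replacements both fall beyond the scatter from it, while nothing available gives a reason for this.

What the three compounds leave open is whether the distinction belongs to hydroxy alone, or whether an amine, a methoxy group or a carboxylic acid on the same carbon would read like compound 1 or fall with compound 2 and compound 3. They also leave open whether moving hydroxy to another carbon of this ring would keep the reading of compound 1.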